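This account rests on a few compounds, and the source may have more. Where it says the series, first, only, none or still open, it means among the compounds named here.

Compound 1, with structure `Nc1scc(CN2CCN(c3cc(Cl)cc(Cl)c3)CC2)c1C(=O)c1ccc(Cl)cc1`, is the starting point. In a functional assay on CHO cells with adenosine receptor A1 (Homo sapiens) as the target, read by cAMP accumulation and immunoassay, with a stated time of 6 min, tested at 0.01 uM (on this read-out lower numbers stand for a stronger effect and higher numbers for a weaker effect at the one concentration tested), compound 1 gives -1%. Two neighbours differ from it only in the group on an amine nitrogen in a ring. Compound 2, `Nc1scc(CN2CCN(c3ccc(Cl)c(C(F)(F)F)c3)CC2)c1C(=O)c1ccc(Cl)cc1`, gives -2.5% in this assay, and compound 3, `Nc1scc(CN2CCN(c3ccc(OC(F)(F)F)cc3)CC2)c1C(=O)c1ccc(Cl)cc1`, gives 0%. Among these three numbers, the one for compound 1 is the second highest, but every gap is small: a number 1.5 percentage points lower from compound 1 to compound 2 (within the scatter), a number 1 percentage points higher from compound 1 to compound 3 (within the scatter) and a number 2.5 percentage points higher from compound 2 to compound 3 (within the scatter) all lie within the usual scatter of repeated measurements, so the three compounds cannot be told apart on this read-out.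

Compound 4 has structure `Nc1scc(CN2CCN(CCCc3ccc(Cl)cc3)CC2)c1C(=O)c1ccc(Cl)cc1`. Compared with compound 1 the change is 3-(4-chlorophenyl)propyl in place of 3,5-dichlorophenyl on an amine nitrogen in a ring. The three measured steps each exchanged one six-membered aromatic ring of carbon only for another at that place and moved the number by no more than the scatter. Among the compounds with values here, none of them put a 3-(4-chlorophenyl)propyl chain there, so no measured step covers this exact change; the nearest evidence, from the within-scatter steps above, points to a small effect at this single concentration.

The expectation for compound 4 is therefore a number 1 percentage points higher from compound 1 to compound 4 (within the scatter), a step that stays within the scatter. Compound 4 is estimated to give 0% in this assay, with a range from -12% to 12%.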

Compound 4, a percentage reported as activity, at one concentration (the size of the read-out at that concentration, not a potency): 0%
Compound 4: the middle estimate sits on the measured number at the digits printed; the measured number falls inside the stated range.
By their numbers in this assay, from the lowest: compounds 2, 1, 3 and 4 (each within the scatter of the next).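

Until now, every group on this amine nitrogen was an aromatic ring of carbon only, attached to the nitrogen itself, whereas compound 4 carries its ring at the end of a 3-(4-chlorophenyl)propyl chain. In this assay this larger change still gives a number 1 percentage points higher from compound 1 to compound 4 (within the scatter) and no change at the digits printed from compound 3 to compound 4 (within the scatter) and a number 2.5 percentage points higher from compound 2 to compound 4 (within the scatter). At this single concentration, then, the position accepts this chain as well as the three directly attached rings, with no difference that can be read between the four compounds, and no supporting measurement is available to explain this result.

From the compounds shown here alone, it remains open whether a benzyl group, a longer chain ending in the same ring, or a chain carrying a carboxylic acid or an amine at this nitrogen would give a number outside the usual scatter. This read-out also comes from one concentration, so these compounds could still differ in the strength of their effect at other concentrations in ways that these numbers cannot show.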